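The source may hold more compounds than are shown below. What is called first, only, known or untested is meant among the compounds shown, and "the series" means these compounds.

- compound 1 `Cc1nc(-c2ccccc2)c(C(=O)N2CCN(c3ccccc3Cl)CC2)o1`: 124 nM
- compound 2 `CCOc1cccc(N2CCN(C(=O)c3oc(C)nc3-c3ccccc3)CC2)c1`: 151 nM

Of the compounds shown here, two sharing one core have been measured so far in a functional assay on HL-60 cells (Homo sapiens) for inhibition, read by MTT assay, with a stated time of 72 h; a higher number here means a weaker inhibitor, a lower number a stronger inhibitor. For the measured compounds named here, compound 2 gives 151 nM, and its only neighbour on the scale is compound 1. The gap between them is a 1.2-fold higher number from compound 1 to compound 2 (0.09 log units; within the scatter), so the two compounds stand level, and neither can be called the better inhibitor.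

The next compound is compound 3 `Cc1nc(-c2ccccc2)c(C(=O)N2CCN(c3ccc(F)cc3)CC2)o1`, which keeps the shared core and changes one group: 4-fluorophenyl in place of 3-ethoxyphenyl on an amine nitrogen in a ring. In words, 4-fluorophenyl takes the place of 3-ethoxyphenyl on an amine nitrogen in a ring.

Going by the values given here, only one measured step bears on this change. Compound 2 differs from compound 1 at this same place, and that step, a 1.2-fold higher number from compound 1 to compound 2 (0.09 log units; within the scatter), stayed within the scatter. Among the compounds with values here, no measured compound carries a 4-fluorophenyl group, so this single step is thin evidence, and a step beyond the scatter is not expected.

The expected step is a 1.1-fold lower number from compound 2 to compound 3 (0.05 log units; within the scatter).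

For compound 3 the estimated value in this assay is 135 nM, with an expected range from 60 nM to 300 nM.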

Compound 3, half-maximal inhibitory concentration: > 1000 nM
Compound 3 gave a limit, no number; the forecaster's own chance of this, stated with the estimate: 2%; middle value at least 7.4-fold (0.86 log units) away from the limit.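

In this assay, the result for compound 3 is a limit of the assay and not a number: the limit of > 1000 nM in this assay, at which 1 of the 3 values shown sits.

Compounds 1 and 2 stood level, which could have suggested that the aromatic group on this amine nitrogen in a ring hardly matters, but that reading does not hold. Putting 4-fluorophenyl at this place gives an at least 6.6-fold higher number from compound 2 to compound 3 (0.82 log units; beyond the scatter), and against the other earlier compound it gives an at least 8.0-fold higher number from compound 1 to compound 3 (0.90 log units; beyond the scatter), so both steps lie beyond the scatter and the choice of group here can decide the outcome, even though all three compounds carry a six-membered aromatic ring of carbon only at this place.

As far as these compounds go, how large the loss really is stays unknown, since the result for compound 3 gives only a bound. The three groups differ both in what they carry and in where they carry it, so a plain phenyl, 2-fluorophenyl or 4-ethoxyphenyl group would be needed to tell whether the fluorine itself or its place on the ring goes with the loss.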